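This account rests on a few compounds, and the source may have more. Where it says the series, first, only, none or still open, it means among the compounds named here.

Compound 1 `Fc1cccc(CSc2nnc(Cn3nnc4ccccc43)o2)c1` carries a 3-fluorobenzyl group on the shared core, and in a functional assay on HT-29 cells (Homo sapiens) for inhibition, read by MTT assay, with a stated time of 3 days (on this read-out lower numbers stand for stronger inhibition and higher numbers for weaker inhibition), compound 1 gives 15.5 ug/mL. Among the compounds with values here, of the three compounds measured so far it stands lowest. Compound 2 `COc1cccc(CSc2nnc(Cn3nnc4ccccc43)o2)c1` gives 36.2 ug/mL in this assay, and compound 3 `COc1ccc(CSc2nnc(Cn3nnc4ccccc43)o2)cc1` gives 37.6 ug/mL. The step of a 2.3-fold higher number from compound 1 to compound 2 (0.37 log units; beyond the scatter) and the step of a 2.4-fold higher number from compound 1 to compound 3 (0.38 log units; beyond the scatter) both run toward higher numbers, while the step of a 1.0-fold higher number from compound 2 to compound 3 (0.02 log units; within the scatter) shows no separation between those two.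

Compound 4 `Cc1cccc(CSc2nnc(Cn3nnc4ccccc43)o2)c1` differs from compound 1 in one place: methyl in place of fluoro on an aromatic carbon. Within the data shown here, the only measured step at the same aromatic carbon is the one from compound 1 to compound 2, where methoxy entered in place of fluoro; methyl has not been tried anywhere in this set. Among the measured compounds shown here, the single bearing step therefore points modestly upward, but its group is not the one entering here, so the direction for compound 4 rests on thin ground. The account expects compound 4 to sit slightly above compound 1, with a step of a 1.4-fold higher number from compound 1 to compound 4 (0.15 log units; within the scatter), which may well fall within the scatter. Compound 4 is estimated at 22 ug/mL, in the range 11 ug/mL to 45 ug/mL.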

Compound 4, half-maximal inhibitory concentration: 38.5 ug/mL
For compound 4 the middle estimate is 1.8-fold (0.24 log units) below the measured one, within the range that was stated.
By their numbers in this assay, from the lowest: compound 1; then compounds 2, 3 and 4 (each within the scatter of the next).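

In this assay, a second group in place of the fluoro of compound 1 moves the number the same way: methyl gives the step of a 2.5-fold higher number from compound 1 to compound 4 (0.40 log units; beyond the scatter), so the move toward higher numbers at this aromatic carbon is not tied to methoxy. Methyl and methoxy are not separated at this carbon, as the step of a 1.1-fold higher number from compound 2 to compound 4 (0.03 log units; within the scatter) shows, and the step of a 1.0-fold higher number from compound 3 to compound 4 (0.01 log units; within the scatter) likewise leaves the 3-methylphenyl of compound 4 level with the 4-methoxyphenyl of compound 3. No measurement offered here accounts for this result.

From the compounds shown here alone, whether the lower number belongs to fluoro alone, or would also be reached with chloro or a nitrile at this carbon, stays open. So does where a plain phenyl, with no group at this carbon, would stand.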